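The compounds below may be only part of what the source reports. "The series", "measured", "known", "first", "only" and "open" are said of these compounds alone.

Measured compounds in the series:
compound 1, `CN(C)c1ccc(C(=O)N[C@H](CCCCCC(=O)NO)C(=O)NCc2ccccc2)cc1`, 1000 nM
compound 2, `O=C(CCCCC[C@H](NC(=O)c1ccc(Br)cc1)C(=O)NCc1ccccc1)NO`, 5860 nM
compound 3, `O=C(CCCCC[C@H](NC(=O)CCCc1c[nH]c2ccccc12)C(=O)NCc1ccccc1)NO`, 7030 nM

All three share the hydroxamic acid side chain and the benzylamide, and differ only in the acyl group on the amide-type nitrogen. In a functional assay on NFF cells (Homo sapiens) for antiproliferative activity (on this read-out lower numbers stand for stronger inhibition and higher numbers for weaker inhibition), compound 1 gives 1000 nM, the lowest number of the three and beyond the scatter from the other two. Compound 2 gives 5860 nM and compound 3 gives 7030 nM; these two lie within the scatter of each other, so no order between them can be read.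

Compound 4, `O=C(/C=C/c1c[nH]c2ccccc12)N[C@@H](CCCCCC(=O)NO)C(=O)NCc1ccccc1`, has not been measured. It differs from compound 2 as follows: 2-(1H-indol-3-yl)ethenyl in place of 4-bromophenyl on a carbonyl carbon. Within the data shown here, no measured pair isolates this change. Compound 3 carries the same indole on a saturated three-carbon linker, so the unsaturated linker of compound 4 is the open question. With compound 3 at 7030 nM, the expected step in this assay is small, towards a lower number, at the edge of the scatter: from compound 2 the step is estimated as a 1.5-fold lower number from compound 2 to compound 4 (0.17 log units; within the scatter). Compound 4 is expected to give about 4000 nM, within 1500 nM to 12000 nM.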

Compound 4, half-maximal inhibitory concentration: 10400 nM
Estimate against measurement, compound 4: 2.6-fold (0.41 log units) below; the measured number falls inside the stated range.
By their numbers in this assay, from the lowest: compound 1; then compounds 2, 3 and 4 (each within the scatter of the next).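

In this assay, a 1.8-fold higher number from compound 2 to compound 4 (0.25 log units; within the scatter) stays within the scatter, so on a carbonyl carbon whose other neighbours are amide-type nitrogen, 2-(1H-indol-3-yl)ethenyl and 4-bromophenyl cannot be told apart. The added five-membered aromatic ring, double bond and hydrogen-bond donor therefore bring no readable change at this position, and compound 4 joins compounds 2 and 3 in a run where each lies within the scatter of the next, while compound 1 keeps the lowest number at 1000 nM. No measurement at hand accounts for this result.

Open, as far as these compounds go, is whether a primary amine or a methoxy group in place of the bromine of compound 2 would approach the number of compound 1. Also open, from the compounds shown here alone, is the part played by the double bond alone, which a saturated two-carbon chain carrying the same indole would separate from chain length.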